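The source may hold more compounds than are shown below. What is called first, only, known or untested is meant among the compounds shown, and "the series" means these compounds.

Measured so far in an assay on HEK293 cells for binding affinity to 5-hydroxytryptamine receptor 7 (Homo sapiens), read by radioligand binding, tested at 1 uM; on this read-out higher numbers stand for more inhibition at the one concentration tested (going by the name of the read-out) and lower numbers for less inhibition:
- compound 1 `Brc1ccc2ccn(CCN3CCCN4CCCCC4C3)c2c1` gives 99%
- compound 2 `CN1CCCN(CCn2ccc3ccc(O)cc32)CC1` gives 28%
- compound 3 `CN1CCCN(CCn2ccc3ccc(C(N)=O)cc32)CC1` gives 33%

Compound 3 holds the second highest of these three numbers. Its nearest neighbour is compound 2, and the two sit within the scatter of repeated measurements, so no order between them can be read. Within the data shown here, compound 1 lies far higher, a gap beyond the scatter, but compound 1 differs from compound 3 in more than one place, so no single step connects them.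

Compound 4 `C#Cc1ccc2ccn(CCN3CCCN(C)CC3)c2c1` differs from compound 3 in one place:
ethynyl in place of carbamoyl on an aromatic carbon

Among the measured compounds shown here, the only measured single step is a number 5 percentage points higher from compound 2 to compound 3 (within the scatter), an exchange of one group on an aromatic carbon that stayed within the scatter. For the measured compounds named here, no measured step exchanges carbamoyl for ethynyl, so the expectation rests mainly on that small step and on the low level of compound 3. Compound 4 is therefore expected to give about 42%, plausibly between 15% and 75%. The expected step is a number 9 percentage points higher from compound 3 to compound 4 (within the scatter), a change that may or may not exceed the scatter.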

Compound 4, a percentage reported as inhibition, at one concentration (the size of the read-out at that concentration, not a potency): 79%
Estimate against measurement, compound 4: 37 percentage points below; measured number outside the range, above it.
By their numbers in this assay, from the lowest: compounds 2 and 3 (each within the scatter of the next); then compound 4; then compound 1.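

With hydroxy and carbamoyl alone, this aromatic carbon looked as if the group on it hardly mattered in this assay but the ethynyl group shows that a change here can move the number strongly. Ethynyl in place of carbamoyl gives a number 46 percentage points higher from compound 3 to compound 4 (beyond the scatter) and ethynyl in place of hydroxy gives a number 51 percentage points higher from compound 2 to compound 4 (beyond the scatter) so the rise holds against both of the earlier groups. Nothing measured here explains why ethynyl stands so far apart from them.

The compounds shown leave open whether the triple bond itself matters, which a vinyl or an ethyl group on the same carbon could test. They also leave open how other groups there, such as a nitrile, a methoxy or an amine, would compare with ethynyl.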